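Aryl sulfone in place of benzyl sulfone on the shared core

A few compounds are considered here, and "the series" means these few. Any claim that something is new, unique, unknown or untested is made for them only; others in the source may bear on it.

Measured compounds:
compound 1 `Cn1c(=O)c(S(=O)(=O)Cc2ccc(F)cc2F)cc2cnc(Nc3ccc4[nH]ccc4c3)nc21` — 1000 nM
compound 2 `Cn1c(=O)c(S(=O)(=O)c2ccc(F)cc2F)cc2cnc(Nc3ccc4cccc(O)c4n3)nc21` — 5000 nM

In a functional assay on DU-145 cells (Homo sapiens) for inhibition, read by trypan blue exclusion, with a stated time of 72 h (a lower number here means a stronger inhibitor, a higher number a weaker inhibitor), compound 1 gives 1000 nM, the lowest of the two numbers, and compound 2 gives 5000 nM, a gap beyond the scatter. Compound 2 differs from compound 1 in more than one place, so no single step can be read from that pair. Compound 3 `COc1ccc(S(=O)(=O)c2cc3cnc(Nc4ccc5[nH]ccc5c4)nc3n(C)c2=O)cc1` changes compound 1 in one place: 4-methoxyphenyl in place of 2,4-difluorobenzyl on a sulfonyl sulfur. Nothing measured isolates this change. The step of a 1.5-fold higher number from compound 1 to compound 3 (0.18 log units; within the scatter) is expected to be small, likely within the scatter. Compound 3 is estimated at 1500 nM, between 500 nM and 5000 nM.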

Compound 3, half-maximal inhibitory concentration: 500 nM
The estimate for compound 3 lay 3.0-fold (0.48 log units) above the measured number; measured number inside the range.
By their numbers in this assay, from the lowest: compounds 3 and 1 (each within the scatter of the next); then compound 2.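

In this assay, within the data shown here, the step of a 2.0-fold lower number from compound 1 to compound 3 (0.30 log units; within the scatter) gives the first single-change reading at this position. The sulfonyl sulfur on the shared core tolerates 4-methoxyphenyl in place of 2,4-difluorobenzyl, with no separation in number that exceeds the scatter. Nothing measured accounts for this outcome. From the compounds shown here alone, whether an amine or a carboxylic acid on the phenyl ring in place of the methoxy group would move the number beyond the scatter remains open. So does the effect of a longer chain on the sulfonyl sulfur.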